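Compound 2 to compound 3: a formyl group replaced

The source may report more compounds than this note shows. Statements on the series, on what has been measured and on what is new or still open speak of the compounds shown alone.

Compound 1 `COC(=O)CCCCCCCCCCCCCC/C=C1\CC(CO)(COC(=O)C(C)(C)C)OC1=O`: > 10 ug/mL
Compound 2 `CC(C)(C)C(=O)OCC1(CO)C/C(=C\CCCCCCCCCCCCCCC=O)C(=O)O1`: > 10 ug/mL

In a functional assay on MOLT-4F cells (Homo sapiens) for antiproliferative activity (a lower number here means a stronger inhibitor of growth, a higher number a weaker inhibitor of growth), compound 2 stands at a limit, > 10 ug/mL, and not at a number. Neither compound has more than this to show: the limit of > 10 ug/mL in this assay, at which 2 of the 2 values shown sit. The change to compound 3 `CC(C)(C)C(=O)OCCCCCCCCCCCCCCC/C=C1\CC(CO)(COC(=O)C(C)(C)C)OC1=O` is (((tert-butyl)carbonyl)oxy)methyl in place of formyl on a saturated chain carbon, ten or more bonds along the chain from a double-bonded chain carbon. Among the compounds with values here, the one measured step that bears on it is a step that the two limits leave unreadable from compound 1 to compound 2, and it offers no size to carry over. No clear change is therefore expected in this assay, and the expected step that the limit leaves unreadable from compound 2 to compound 3 is only a rough guess. For compound 3 the estimate is 15 ug/mL, with an expected range of 7 ug/mL to 40 ug/mL.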

Compound 3, concentration for 50% growth inhibition: 0.605 ug/mL
Estimate against measurement, compound 3: 25-fold (1.39 log units) above; the whole stated range lies above it.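

In this assay, the far end of the chain clearly matters: placing (((tert-butyl)carbonyl)oxy)methyl on this saturated chain carbon in place of formyl brings an at least 16-fold lower number from compound 2 to compound 3 (1.21 log units; beyond the scatter), and placing it there in place of methoxycarbonyl brings an at least 16-fold lower number from compound 1 to compound 3 (1.21 log units; beyond the scatter). Growth inhibition at this position therefore depends strongly on the group at the chain end. Both steps are minimum sizes only, because the two starting compounds give limits and not numbers: the limit of > 10 ug/mL in this assay, at which 2 of the 3 values shown sit.

Which part of the entering group counts remains open. A hydroxyl or a carboxylic acid at the chain end, or a shorter chain carrying the same ester, would help to separate the ester from its tert-butyl part.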